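Chain-length step in a quinazoline hydrazone series on HT-29 cells

The source may report more compounds than this note shows. Statements on the series, on what has been measured and on what is new or still open speak of the compounds shown alone.

Measured so far:
- compound 1 `CN(C)CCNc1nc(N/N=C/c2ccc(F)cc2Cl)nc2ccccc12`: 330 nM
- compound 2 `CN(C)CCCNc1nc(N/N=C/c2ccc(F)cc2Cl)nc2ccccc12`: 1150 nM
- compound 3 `CN(C)CCNc1nc(N/N=C/c2nccn2Cc2ccccc2)nc2ccccc12`: 2620 nM

In a functional assay on HT-29 cells (Homo sapiens) for cytotoxicity, read by MTT assay, with a stated time of 72 h (on this read-out lower numbers stand for stronger inhibition and higher numbers for weaker inhibition), compound 1 gives 330 nM and compound 2 gives 1150 nM. The change between them is (dimethylamino)methyl in place of dimethylamino on a saturated chain carbon, two bonds along the chain from a nitrogen on an aromatic ring, and it produced a 3.5-fold higher number from compound 1 to compound 2 (0.54 log units; beyond the scatter).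

Compound 3 carries a different core; how its core differs from that of compound 1 is not broken down here. In this assay compound 3 gives 2620 nM, the highest number of the three measured compounds.

Compound 4 `CN(C)CCCNc1nc(N/N=C/c2nccn2Cc2ccccc2)nc2ccccc12` has not yet been measured. It stands to compound 3 as compound 2 stands to compound 1: the change is (dimethylamino)methyl in place of dimethylamino on a saturated chain carbon, two bonds along the chain from a nitrogen on an aromatic ring, the same change at the same place. For the measured compounds named here, only one earlier instance of this change is available, so the expectation rests on that single step. For compound 4 in this assay a step of about a 3.1-fold higher number from compound 3 to compound 4 (0.48 log units; beyond the scatter) is expected, resting on the step of a 3.5-fold higher number from compound 1 to compound 2 (0.54 log units; beyond the scatter) seen on the other core. Compound 4 is therefore estimated at 8000 nM, with a plausible range from 3000 nM to 20000 nM.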

Compound 4, half-maximal inhibitory concentration: 1980 nM
For compound 4 the middle estimate is 4.0-fold (0.61 log units) above the measured one; the measured number lies below the stated range.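

In this assay, the change from dimethylamino to (dimethylamino)methyl does not carry over from the core of compound 1 to the other core, where the new step reads a 1.3-fold lower number from compound 3 to compound 4 (0.12 log units; within the scatter). The two instances of the same change differ: the same change on two cores in this assay, a 3.5-fold higher number (0.54 log units; beyond the scatter) from compound 1 to compound 2 and a 1.3-fold lower number (0.12 log units; within the scatter) from compound 3 to compound 4, 4.6-fold (0.66 log units) apart, beyond the scatter of two such steps. With a single pair on each core, this shows only that the step seen on one core was not a reliable guide to the other here; it does not show what sets the two cores apart, or whether either step would hold for other pairs on the same core.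

From the compounds shown here alone, it remains open how a longer chain, or a cyclic amine such as piperidine or morpholine in place of dimethylamino, would behave on each core. Going by these compounds, it is also open whether a further pair of cores would follow the pattern of the first pair, the second pair or neither, and whether the difference between the two steps would persist in other cell lines.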